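Lengthening an ester chain on a potent isatin derivative

This account rests on a few compounds, and the source may have more. Where it says the series, first, only, none or still open, it means among the compounds named here.

Measured compounds in a functional assay on K562 cells (Homo sapiens) for cytotoxicity, read by MTT assay, with a stated time of 48 h; on this read-out higher numbers stand for weaker inhibition and lower numbers for stronger inhibition:
compound 1, `COC(=O)/C=C/c1ccc2c(c1)C(=O)C(=O)N2Cc1ccc(OC)cc1`, gives 3 nM.
compound 2, `COC(=O)/C=C/c1ccc2c(c1)C(=O)C(=O)N2Cc1cc(C)cc(C)c1`, gives 40 nM.
compound 3, `COC(=O)/C=C/c1ccc2c(c1)C(=O)C(=O)N2Cc1ccc(C(F)(F)F)cc1`, gives 40 nM.

Compound 1 has the lowest number of the three and so is the strongest inhibitor shown; the step of a 13-fold higher number from compound 1 to compound 2 (1.12 log units; beyond the scatter) and the step of a 13-fold higher number from compound 1 to compound 3 (1.12 log units; beyond the scatter) both move well beyond the scatter.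

Compound 4, `CCOC(=O)/C=C/c1ccc2c(c1)C(=O)C(=O)N2Cc1ccc(OC)cc1`, is not yet measured. It differs from compound 1 in one place: methyl in place of hydrogen on a saturated chain carbon bound to an oxygen next to a carbonyl group. The same difference, cut one bond further out, reads methoxycarbonyl to ethoxycarbonyl.

Both measured steps change the group on the saturated chain carbon bound to the amide-type nitrogen in the ring; neither touches the chain carbon bound to an oxygen next to a carbonyl group. Going by the values given here, no measured step therefore bears directly on this change, and the expectation is a step within the scatter in this assay, with a slight lean toward a higher number.

Compound 4 is expected to give 5 nM (range 1.5 nM to 15 nM), a step of a 1.7-fold higher number from compound 1 to compound 4 (0.22 log units; within the scatter).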

Compound 4, half-maximal inhibitory concentration: 10 nM
Beside the measured number, compound 4's estimate is 2.0-fold (0.30 log units) below it, and the stated range covers the measured number.
By their numbers in this assay, from the lowest: compound 1; then compound 4; then compounds 2 and 3 (each within the scatter of the next).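

The earlier compounds shown here varied only the group on the saturated chain carbon bound to the amide-type nitrogen, so they said nothing about the ester. Here, in this assay, methoxycarbonyl to ethoxycarbonyl, a gain of a single carbon, gives a 3.3-fold higher number from compound 1 to compound 4 (0.52 log units; beyond the scatter), so this position does respond to even a small change, and since the two compounds differ nowhere else, the step belongs to this change alone. Nothing in the data explains why the added methyl has this effect.

One lengthening cannot show whether a longer chain such as propyl or butyl would raise the number further, or how a carboxylic acid or an amide would fare in place of the ester. From the compounds shown here alone, it also remains open whether the same methyl would give a similar step on compound 2 or compound 3.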